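From compound 3 to compound 4: an oxan-4-yl swap

A few compounds are considered here, and "the series" means these few. Any claim that something is new, unique, unknown or untested is made for them only; others in the source may bear on it.

In a toxicity assay on HeLa cells (Homo sapiens) for cytotoxicity (a higher number here means that more compound is tolerated, a lower number that less compound is tolerated), compound 1 `COc1nc(C(C)(C)C)ccc1[C@@H](c1ccccc1)[C@@](O)(CCN(C)C)c1cccc2ccccc12` gives > 64 ug/mL, which is a limit and not a number. Compound 2 `COc1ccc(-c2ccc([C@@H](c3ccccc3)[C@@](O)(CCN(C)C)c3cccc4ccccc34)c(OC)n2)cc1` gives > 64 ug/mL, which is also a limit. Compound 3 `COc1nc(-c2ccc(OC(F)(F)F)cc2)ccc1[C@@H](c1ccccc1)[C@@](O)(CCN(C)C)c1cccc2ccccc12` gives > 64 ug/mL, again a limit and not a number. The series therefore stands as follows: the limit of > 64 ug/mL in this assay, at which 3 of the 3 values shown sit. Compound 3 has no exact value from which to count a step.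

The next structure is compound 4 `COc1nc(C2CCOCC2)ccc1[C@@H](c1ccccc1)[C@@](O)(CCN(C)C)c1cccc2ccccc12`, with oxan-4-yl in place of 4-(trifluoromethoxy)phenyl on an aromatic carbon.

For the measured compounds named here, three measured steps bear on this change: a step that the two limits leave unreadable from compound 1 to compound 2, a step that the two limits leave unreadable from compound 1 to compound 3 and a step that the two limits leave unreadable from compound 2 to compound 3. Going by the values given here, the first two exchange the group on the same aromatic carbon, but none of the three has a size that can be read. They therefore support no direction in this assay, and no step beyond the scatter is expected. The expected step is a number no higher from compound 3 to compound 4 (the limit leaves the size open), with no direction implied. For compound 4 the estimate is 64 ug/mL, with an expected range from 32 ug/mL to 128 ug/mL, and another limit is the most likely report.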

Compound 4, half-maximal cytotoxic concentration: 22.5 ug/mL
Beside the measured number, compound 4's estimate is 2.8-fold (0.45 log units) above it, and the stated range ends above it.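

For the compounds shown here, the group on the aromatic carbon next to the ring nitrogen can move the number in this assay, which the earlier compounds could not show, and oxan-4-yl gives the first readable steps: an at least 2.8-fold lower number from compound 3 to compound 4 (0.45 log units; beyond the scatter) and an at least 2.8-fold lower number from compound 2 to compound 4 (0.45 log units; beyond the scatter) and also an at least 2.8-fold lower number from compound 1 to compound 4 (0.45 log units; beyond the scatter) in the same direction. The direction holds whichever group leaves, whether 4-(trifluoromethoxy)phenyl, 4-methoxyphenyl or tert-butyl, so none of the three groups goes against it. Among the compounds shown, only compound 4 has an exact value, and the others remain at the assay limit: the limit of > 64 ug/mL in this assay, at which 3 of the 4 values shown sit.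

From the compounds shown here alone, the steps among compound 1, compound 2 and compound 3 cannot be read, and the true size of each step to compound 4 stays open while those three compounds are known only by a limit. Also open, going by these compounds, is whether a cyclohexyl ring, which has no ring oxygen, or a piperidin-4-yl amine on the same aromatic carbon would give a similar number in this assay or remain at the limit.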